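Chloro for fluoro across two closely related cores

The source may hold more compounds than are shown below. What is called first, only, known or untested is meant among the compounds shown, and "the series" means these compounds.

Four compounds share one core and differ at two places. Compound 1 `CN1CCN(c2ccc(S(=O)(=O)Oc3cccc(F)c3)cc2)C1=O` carries the fluoro and the methyl; compound 2 `CN1CCN(c2ccc(S(=O)(=O)Oc3cccc(Cl)c3)cc2)C1=O` carries the chloro in place of the fluoro; compound 3 `CCN1CCN(c2ccc(S(=O)(=O)Oc3cccc(F)c3)cc2)C1=O` carries the fluoro and the ethyl; compound 4 `CCN1CCN(c2ccc(S(=O)(=O)Oc3cccc(Cl)c3)cc2)C1=O`, not yet measured, combines the ethyl with the chloro.

In a functional assay on HT-29 cells (Homo sapiens) for antiproliferative activity, read by sulforhodamine B assay, with a stated time of 48 h (on this read-out higher numbers stand for weaker inhibition and lower numbers for stronger inhibition), compound 1 gives only a limit, > 100000 nM. Compound 2 gives 2100 nM in this assay. In this assay compound 3 likewise gives only a limit, > 100000 nM. Two of the three values therefore sit at the limit of > 100000 nM in this assay, at which 2 of the 3 values shown sit, which leaves the series thinly anchored.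

The change chloro in place of fluoro on an aromatic carbon produced an at least 47-fold lower number from compound 1 to compound 2 (1.67 log units; beyond the scatter). The step that the two limits leave unreadable from compound 1 to compound 3 is not readable. The two cores differ by methyl in place of hydrogen on a saturated chain carbon bound to an amide-type nitrogen in a ring.

From compound 3 to compound 4 the change is chloro in place of fluoro on an aromatic carbon, and the surroundings of the place are described in the same words as for compound 1 to compound 2, so it is the same change. The expected step is an at least 25-fold lower number from compound 3 to compound 4 (1.39 log units; beyond the scatter). This expectation rests on the step of an at least 47-fold lower number from compound 1 to compound 2 (1.67 log units; beyond the scatter), read as the only measured effect of this change in this assay, while the starting point of compound 3 is itself only a limit. Compound 4 is estimated at 4000 nM in this assay, expected to fall between 1000 nM and 40000 nM.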

Compound 4, half-maximal inhibitory concentration: 6800 nM
Compound 4: middle estimate off by 1.7-fold (0.23 log units), on the low side; the measured number falls inside the stated range.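

In this assay, chloro in place of fluoro on an aromatic carbon carries over to the ethyl core in direction, giving an at least 14-fold lower number from compound 3 to compound 4 (1.16 log units; beyond the scatter), so in the two pairs shown the 3-chlorophenyl compound gives the lower number on both cores. The size of the change cannot be compared between the cores, and a true size on either core remains unknown: the same change on two cores in this assay, an at least 47-fold lower number (1.67 log units; beyond the scatter) from compound 1 to compound 2 and an at least 14-fold lower number (1.16 log units; beyond the scatter) from compound 3 to compound 4; the limit leaves it open whether they differ

With the chloro held fixed, the core change gives a 3.2-fold higher number from compound 2 to compound 4 (0.51 log units; beyond the scatter), a modest step that is readable only on this pair, whereas the corresponding step between the two fluoro compounds cannot be read: the limit of > 100000 nM in this assay, at which 2 of the 4 values shown sit.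

The compounds shown leave open whether the step carries to cores with a longer chain, such as propyl or butyl, in place of the methyl or ethyl. They also leave open how a bromo, a methoxy or a nitrile in place of the chloro on the aromatic carbon would read in this assay, and two cores are too few to say that the change would carry further.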